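This account rests on a few compounds, and the source may have more. Where it says the series, first, only, none or still open, it means among the compounds named here.

In a functional assay on HCC827 cells (Homo sapiens) for antiproliferative activity, read by MTT assay, with a stated time of 72 h (a lower number here means a stronger inhibitor, a higher number a weaker inhibitor), compound 1 (`CN1CCN(c2ccc(Nc3ncc4nc(Nc5ccc(F)cc5)n([C@H]5CCCN(C(=O)CO)C5)c4n3)cc2)CC1`) gives 1.8 nM and holds the lower of the two numbers, with compound 2 (`CN1CCN(c2ccc(Nc3ncc4nc(Nc5ccccc5)n([C@@H]5CCNC5)c4n3)cc2)CC1`) at 65 nM beyond the scatter above it. Compound 3 (`CN1CCN(c2ccc(Nc3ncc4nc(Nc5ccc(F)cc5)n([C@@H]5CCCNC5)c4n3)cc2)CC1`) has piperidin-3-yl in place of 1-((hydroxymethyl)carbonyl)piperidin-3-yl on an aromatic nitrogen. For the measured compounds named here, no measured pair isolates this change. Compound 2 (65 nM) also lacks that carbonyl group, but differs elsewhere too, so the evidence is indirect. In this assay the expected step, towards weaker inhibition and beyond the scatter, is (a 6.7-fold higher number from compound 1 to compound 3 (0.82 log units; beyond the scatter)). The estimate for compound 3 is 12 nM (expected range 3 nM to 50 nM).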

Compound 3, half-maximal inhibitory concentration: 120 nM
Estimate against measurement, compound 3: 10-fold (1.00 log units) below, outside the stated range (above it).
By their numbers in this assay, from the lowest: compound 1; then compounds 2 and 3 (each within the scatter of the next).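

In this assay, for the compounds shown here, replacing 1-((hydroxymethyl)carbonyl)piperidin-3-yl with piperidin-3-yl on the aromatic nitrogen gives a 67-fold higher number from compound 1 to compound 3 (1.82 log units; beyond the scatter) with the (4-fluorophenyl)amino group held constant, the first direct reading of this change. The substituent on the piperidine nitrogen therefore matters greatly to the activity of compound 1 at this position. No available evidence accounts for the size of this step.

Still open, on these data alone, is whether the hydroxyl or the carbonyl carries the difference. An acetyl group or a plain methyl on the piperidine nitrogen would separate the two.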